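A tert-butyl group added to compound 1

This account rests on a few compounds, and the source may have more. Where it says the series, first, only, none or still open, it means among the compounds named here.

In a functional assay on Ramos cells (Homo sapiens) for antiproliferative activity (on this read-out higher numbers stand for weaker inhibition and lower numbers for stronger inhibition), compound 1 `Nc1ncnc2c1c(-c1ccc(NC(=O)c3ccccc3)cc1)cn2[C@H]1CCN(C[C@@H]2CO2)C1` gives 2250 nM and shares the low end of the three measured numbers with compound 2 `CC(C)(C)c1ccc(COc2ccc(-c3cn([C@H]4CCN(C[C@@H]5CO5)C4)c4ncnc(N)c34)cc2)cc1` at 4210 nM with no gap beyond the scatter, while compound 3 `CC(C)(C)c1ccc(Oc2ccc(-c3cn([C@H]4CCN(C[C@@H]5CO5)C4)c4ncnc(N)c34)cc2)cc1` stands apart at 11200 nM on the high side. Compound 4 `CC(C)(C)c1ccc(C(=O)Nc2ccc(-c3cn([C@H]4CCN(C[C@@H]5CO5)C4)c4ncnc(N)c34)cc2)cc1` differs from compound 1 by one change (tert-butyl in place of hydrogen on an aromatic carbon), a tert-butyl in place of hydrogen on an aromatic carbon, para to a large group. Within the data shown here, no measured step makes this exact change. Two measured steps also bring in a tert-butyl, though they replace benzamido outright and so bear only indirectly: a 1.9-fold higher number from compound 1 to compound 2 (0.27 log units; within the scatter) and a 5.0-fold higher number from compound 1 to compound 3 (0.70 log units; beyond the scatter) are the sizes seen. A modest rise toward weaker inhibition is therefore expected, a 1.6-fold higher number from compound 1 to compound 4 (0.19 log units; within the scatter) by this estimate. Compound 4 is expected at 3500 nM (range 1300 nM to 9500 nM).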

Compound 4, half-maximal inhibitory concentration: 2970 nM
Estimate against measurement, compound 4: 1.2-fold (0.07 log units) above, and the stated range covers the measured number.
By their numbers in this assay, from the lowest: compounds 1, 4 and 2 (each within the scatter of the next); then compound 3.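

In this assay the benzamido group stays in place and tert-butyl replaces hydrogen on its aromatic ring, para to a large group, which gives a 1.3-fold higher number from compound 1 to compound 4 (0.12 log units; within the scatter) and leaves the number within the scatter. Among these compounds, the earlier steps replaced benzamido outright, so this is the first step to show tert-butyl added on its own. Nothing shown gives a reason for this result. Still open, on these data alone, is whether a methyl, an amine or a carboxylic acid on this carbon would move the number beyond the scatter.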